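The source may hold more compounds than are shown below. What is called first, only, known or untested is meant among the compounds shown, and "the series" means these compounds.

Of the compounds shown here, two built on the same core have been measured in a functional assay on HL-60 cells (Homo sapiens) for antiproliferative activity, read by MTT assay, with a stated time of 48 h; a higher number here means a weaker inhibitor, a lower number a stronger inhibitor. Compound 1 `COC1=C(OC)C(=O)C(CCCO)=C(C)C1=O` carries a 3-hydroxypropyl chain on that core, and in this assay compound 1 gives 15000 nM. Compound 2 `COC1=C(OC)C(=O)C(CCCCCCCCCCn2ccnc2)=C(C)C1=O` carries a quite different and much longer chain, and in this assay compound 2 gives 15000 nM. At the digits reported, compound 1 stands level with compound 2; the two values lie within the usual scatter of each other, so neither can be set ahead of the other. Compound 3 `COC1=C(OC)C(=O)C(CCCCCO)=C(C)C1=O` has not yet been measured. It differs from compound 1 in one place: 2-hydroxyethyl in place of hydroxy on a saturated chain carbon, three bonds along the chain from a double-bonded ring carbon. Among the measured compounds shown here, no step between two measured compounds covers this change, but the pair of compound 1 and compound 2 shows that a large alteration of the same chain left the readout unchanged within the scatter. On that basis the expected step is no change at the digits printed from compound 1 to compound 3 (within the scatter), in neither direction beyond the scatter. For compound 3 an inhibitory concentration near 15000 nM is estimated, with a range from 7000 nM to 32000 nM.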

Compound 3, half-maximal inhibitory concentration: 8000 nM
Estimate against measurement, compound 3: 1.9-fold (0.27 log units) above; low and high end bracket the measured number.
By their numbers in this assay, from the lowest: compounds 3, 1 and 2 (each within the scatter of the next).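

In this assay, putting 2-hydroxyethyl in place of hydroxy on a saturated chain carbon, three bonds along the chain from a double-bonded ring carbon, gives a 1.9-fold lower number from compound 1 to compound 3 (0.27 log units; within the scatter). Among the compounds shown here, this is the first direct reading of this change at this position, and it shows that going from 3-hydroxypropyl to 5-hydroxypentyl, with the terminal hydroxy kept, produces no difference that can be separated from the usual scatter of the assay. The hydroxy-ended chain on the shared core therefore tolerates this added length without a resolved shift in the readout, although a single pair cannot establish a trend. No measurement is available that would explain this result.

The compounds shown leave open whether a longer chain still ending in hydroxy, such as 10-hydroxydecyl, would produce a step beyond the scatter. They also leave open how the readout would respond if the terminal hydroxy of the 5-hydroxypentyl chain were replaced by an amine or a carboxylic acid.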